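The source may report more compounds than this note shows. Statements on the series, on what has been measured and on what is new or still open speak of the compounds shown alone.

In an in vitro ADME assay on microsomes from liver (Mus musculus) for pharmacokinetics (on this read-out higher numbers stand for fast clearance and lower numbers for slow clearance), compound 3 (`COc1ccc(CN([C@@H]2CC(F)(F)CCNC2=O)S(=O)(=O)c2ccc(Cl)cc2)c(F)c1F`) gives 121 mL.min-1.g-1 and lies within the scatter of compound 1 (`COc1ccc(CN([C@@H]2CC(F)(F)CCNC2=O)S(=O)(=O)c2ccc(Cl)cc2)cn1`) with 72 mL.min-1.g-1 while compound 2 (`CC1(C)CCNC(=O)[C@H](N(Cc2ccc(C(=O)NC3CC3)cc2)S(=O)(=O)c2ccc(Cl)cc2)C1`) stands well apart from both with 655 mL.min-1.g-1 as the highest number. Compound 4 (`COc1ccc(CN([C@@H]2CC(F)(F)CCNC2=O)S(=O)(=O)c2ccc(Cl)cc2)c(F)c1`) differs from compound 3 by hydrogen in place of fluoro on an aromatic carbon. Going by the values given here, the one measured step that bears on this is a 1.7-fold higher number from compound 1 to compound 3 (0.23 log units; within the scatter) and it stays within the scatter, although it is a different exchange. Among the compounds with values here, no measured pair shows the removal of a fluoro alone. Resting on that single step, the expected change in this assay stays within the scatter (a 1.2-fold lower number from compound 3 to compound 4 (0.06 log units; within the scatter)). For compound 4 the estimate is 105 mL.min-1.g-1 within an expected range (55 mL.min-1.g-1 to 200 mL.min-1.g-1).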

Compound 4, intrinsic clearance in microsomes: 105 mL.min-1.g-1
Compound 4: the middle estimate sits on the measured number at the digits printed; the range from low to high includes it.
By their numbers in this assay, from the lowest: compounds 1, 4 and 3 (each within the scatter of the next); then compound 2.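

Going by these compounds alone, this is the first measured pair that isolates the loss of a fluoro on this aromatic carbon, and in this assay the step stays within the scatter (a 1.2-fold lower number from compound 3 to compound 4 (0.06 log units; within the scatter)). With one fluoro left, the 2-fluoro-4-methoxyphenyl group also remains within the scatter of the 6-methoxypyridin-3-yl group (a 1.5-fold higher number from compound 1 to compound 4 (0.16 log units; within the scatter)). Going by these compounds, whether a larger group on this carbon, such as trifluoromethyl or an amine, would also leave the number within the scatter stays open. No measurement at hand accounts for these numbers.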